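Carbonyl substituent swaps and the step to compound 4

The compounds below may be only part of what the source reports. "The series", "measured", "known", "first", "only" and "open" are said of these compounds alone.

Values in an ADME assay on MRC5 cells (Homo sapiens) for inhibition, with a stated time of 72 h; a higher number here means that more compound is needed for the effect, a lower number that less compound is needed:
- compound 1 `CO[C@H]1CC[C@H](NC(=O)c2n[nH]cc2NC(=O)c2ccccc2)CC1`: 800 nM
- compound 2 `CO[C@H]1CC[C@H](NC(=O)c2n[nH]cc2NC(=O)c2cc(Cl)cc(Cl)c2)CC1`: 13000 nM
- compound 3 `CO[C@H]1CC[C@H](NC(=O)c2n[nH]cc2NC(=O)C2CCOCC2)CC1`: > 50000 nM

Compound 3 stands at > 50000 nM, which is a limit of the assay and not a number. Compound 4 `CO[C@H]1CC[C@H](NC(=O)c2n[nH]cc2NC(=O)C2CCC(F)(F)CC2)CC1` has 4,4-difluorocyclohexyl in place of oxan-4-yl on a carbonyl carbon. Three measured swaps at this same place bear on the change: a 16-fold higher number from compound 1 to compound 2 (1.21 log units; beyond the scatter), an at least 62-fold higher number from compound 1 to compound 3 (1.79 log units; beyond the scatter) and an at least 3.8-fold higher number from compound 2 to compound 3 (0.58 log units; beyond the scatter). All were beyond the scatter, so a real change in this assay is expected here too, of modest size and towards a lower number. The expected step is an at least 2.0-fold lower number from compound 3 to compound 4 (0.30 log units; that floor lies within the scatter). For compound 4 the estimated value is 25000 nM, with an expected range of 6000 nM to 50000 nM.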

Compound 4, half-maximal effective concentration: > 50000 nM
Compound 4 was reported as a limit (the forecaster's own chance of this, stated with the estimate: 40%); middle value at least 2.0-fold (0.30 log units) from the limit.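

In this assay compound 4 gives > 50000 nM, which is a limit of the assay and not a number. A non-aromatic ring of carbon only therefore does not bring the number back towards the aromatic compounds, with an at least 62-fold higher number from compound 1 to compound 4 (1.79 log units; beyond the scatter) and an at least 3.8-fold higher number from compound 2 to compound 4 (0.58 log units; beyond the scatter). The step between the two non-aromatic rings cannot be read, because compound 3 and compound 4 sit at the same limit: the limit of > 50000 nM in this assay, at which 2 of the 4 values shown sit.

As far as these compounds go, how far compound 3 and compound 4 lie past this limit remains open. Also open, from the compounds shown here alone, is whether an amine on the ring, or a longer chain in its place, would give a readable value.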